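Pyridyloxy variation on the triazolylbenzoyl piperidine core

The source may report more compounds than this note shows. Statements on the series, on what has been measured and on what is new or still open speak of the compounds shown alone.

Measured so far:
compound 1 `C#Cc1ccnc(O[C@@H]2CC[C@@H](C)N(C(=O)c3ccccc3-n3nccn3)C2)c1`: 0.6 nM
compound 2 `C[C@@H]1CC[C@@H](Oc2cc(-c3ccccc3)ccn2)CN1C(=O)c1ccccc1-n1nccn1`: 3.8 nM

In an assay on CHO-K1 cells for displacement of a labelled ligand from Orexin receptor type 2 (Homo sapiens), read by radioligand binding (a lower number here means a stronger inhibitor, a higher number a weaker inhibitor), compound 1 gives the lower of the two numbers, with the nearest neighbour, compound 2, at 3.8 nM. Among the compounds with values here, the only step between measured compounds bears on the aryl ether: a 6.3-fold higher number from compound 1 to compound 2 (0.80 log units; beyond the scatter), which replaces the ethynyl by a phenyl on an aromatic carbon.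

Compound 3 `Cc1cccnc1O[C@@H]1CC[C@@H](C)N(C(=O)c2ccccc2-n2nccn2)C1` is not yet measured. The change is 3-methylpyridin-2-yl in place of 4-ethynylpyridin-2-yl on an oxygen on a saturated carbon. It removes the ethynyl and adds a methyl at a different position of the pyridine, so the measured step informs it only in part; it shows that the ethynyl carries some potency, and losing it is expected to cost somewhat, while the methyl offers no measured reference. A step of about the size seen, or somewhat smaller, is expected in this assay: a 5.0-fold higher number from compound 1 to compound 3 (0.70 log units; beyond the scatter). Compound 3 is estimated at 3 nM, in the range 0.8 nM to 12 nM.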

Compound 3, inhibition constant: 621 nM
Estimate against measurement, compound 3: 210-fold (2.32 log units) below; measured number above the stated range.
By their numbers in this assay, from the lowest: compound 1; then compound 2; then compound 3.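

In this assay, 3-methylpyridin-2-yl in place of 4-ethynylpyridin-2-yl gives a 1000-fold higher number from compound 1 to compound 3 (3.01 log units; beyond the scatter), far larger than the step for phenyl in place of ethynyl, a 6.3-fold higher number from compound 1 to compound 2 (0.80 log units; beyond the scatter). The group on this oxygen is therefore much less forgiving than the phenyl result alone suggested, and losing the ethynyl does not by itself bring a step of this size, as compound 2 also lacks it and stays at 3.8 nM. No measurement here bears on the cause of the large step.

The change removes the ethynyl and places a methyl elsewhere on the pyridine in one move, so the two contributions cannot be separated. An unsubstituted pyridin-2-yl, or a methyl or nitrile in place of the ethynyl, would begin to separate them.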